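A Chloro Analogue in a Series Sitting at the Assay Limit

A few compounds are considered here, and "the series" means these few. Any claim that something is new, unique, unknown or untested is made for them only; others in the source may bear on it.

Measured in a functional assay on PC-3 cells (Homo sapiens) for antiproliferative activity, read by MTT assay, with a stated time of 72 h; on this read-out higher numbers stand for weaker inhibition and lower numbers for stronger inhibition:
Compound 1, `O=C(CNc1ccccc1F)N[C@H]1CCOC1=O`: > 64000 nM
Compound 2, `O=C(CNc1ccc(Cl)cc1Cl)N[C@H]1CCOC1=O`: > 64000 nM
Compound 3, `O=C(CNc1ccccc1)N[C@H]1CCOC1=O`: > 64000 nM

Compound 3 stands nowhere that can be placed among numbers: its value is a limit of the assay, not a measured concentration. The same holds for compound 1, whose value is likewise a limit. Compound 2 also gives only a limit. Among the compounds with values here, all three sit at the limit of > 64000 nM in this assay, at which 3 of the 3 values shown sit, so the one step between measured compounds, a step that the two limits leave unreadable from compound 1 to compound 3, cannot be read in size or direction.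

Compound 4, `O=C(CNc1ccccc1Cl)N[C@H]1CCOC1=O`, differs from compound 3 by chloro in place of hydrogen on an aromatic carbon. Within the data shown here, no measured step bears readably on this change; compound 2, which also carries chloro on the ring, gives nothing beyond its limit. Compound 4 is therefore expected to behave like compound 3, and the step that the limit leaves unreadable from compound 3 to compound 4 is estimated as none that could be read. The estimate for compound 4 in this assay is 100000 nM, within 30000 nM to 400000 nM, most likely again reported only as a limit.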

Compound 4, half-maximal inhibitory concentration: > 64000 nM
Compound 4: no number, only a limit (the forecaster's own chance of this, stated with the estimate: 85%); the middle value does not contradict the limit.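

In this assay compound 4 gives > 64000 nM, which is a limit and not a number. The steps to compound 4 from compound 1, compound 2 and compound 3 therefore cannot be read: the limit of > 64000 nM in this assay, at which 4 of the 4 values shown sit. The compounds shown leave open whether any change on the aromatic ring alters this read-out.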